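Compound 2 to compound 3: exchanging the thiazole group

This account rests on a few compounds, and the source may have more. Where it says the series, first, only, none or still open, it means among the compounds named here.

Values in a toxicity assay on MT2 cells (Homo sapiens) for cytotoxicity, read by XTT assay, with a stated time of 4 days; on this read-out lower numbers stand for higher toxicity in this test and higher numbers for lower toxicity in this test:
Compound 1 `Cc1nc(C)c([C@H](OC(C)(C)C)C(=O)O)c(N2CCC(C)(C)CC2)c1-c1ccc(OCCc2ccc(F)c(F)c2)cc1`: >= 33500 nM (a limit)
Compound 2 `Cc1nc(CCOc2ccc(-c3c(C)nc(C)c([C@H](OC(C)(C)C)C(=O)O)c3N3CCC(C)(C)CC3)cc2)cs1`: >= 25000 nM (a limit)

Compound 2 stands at >= 25000 nM, which is a limit of the assay and not a number. Compound 1 also has only a limit, so this assay offers no exact value for either compound. Compound 3 `Cc1nc(C)c(CCOc2ccc(-c3c(C)nc(C)c([C@H](OC(C)(C)C)C(=O)O)c3N3CCC(C)(C)CC3)cc2)s1` differs from compound 2 in one place: 2,4-dimethyl-1,3-thiazol-5-yl in place of 2-methyl-1,3-thiazol-4-yl on a saturated chain carbon, two bonds along the chain from an oxygen on an aromatic ring. There, 2,4-dimethyl-1,3-thiazol-5-yl replaces 2-methyl-1,3-thiazol-4-yl. For the measured compounds named here, the only measured step bearing on this change is a step that the two limits leave unreadable from compound 1 to compound 2, at the same place. It gives no size, so no step beyond the scatter is expected. The expected change is a step that the limit leaves unreadable from compound 2 to compound 3. The estimated value for compound 3 is 30000 nM, with an expected range of 12000 nM to 70000 nM.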

Compound 3, half-maximal cytotoxic concentration: >= 25000 nM
Compound 3: only a limit was reported; the forecaster's own chance of this, stated with the estimate: 80%; the middle value does not contradict the limit.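

In this assay compound 3 gives >= 25000 nM, which is a limit of the assay and not a number. No new step can be read among compound 1, compound 2 and compound 3. The compounds shown leave open whether exchanging these groups changes the read-out at all.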